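Nitrophenyl for Dichlorophenyl on a Trimethoxy Core

This account rests on a few compounds, and the source may have more. Where it says the series, first, only, none or still open, it means among the compounds named here.

Compound 1 `COc1cc(/C=C2\CN(C)C/C(=C\c3ccc(Cl)c(Cl)c3)C2=O)cc(OC)c1`: 9490 nM
Compound 2 `COc1cc(/C=C2\CN(C)C/C(=C\c3cccc([N+](=O)[O-])c3)C2=O)cc(OC)c1`: 4420 nM
Compound 3 `COc1cc(/C=C2\CN(C)C/C(=C\c3ccc(Cl)c(Cl)c3)C2=O)cc(OC)c1OC`: 16200 nM

Of the compounds shown here, three have been measured in a functional assay on K562 cells (Homo sapiens) for cytotoxicity, read by MTT assay, with a stated time of 24 h; a lower number here means a stronger inhibitor, a higher number a weaker inhibitor. Compound 1 and compound 2 share a core and differ by 3-nitrophenyl in place of 3,4-dichlorophenyl on a double-bonded chain carbon bound to a double-bonded ring carbon; this change gave a 2.1-fold lower number from compound 1 to compound 2 (0.33 log units; beyond the scatter). The core of compound 3 differs from that of compound 1 by methoxy in place of hydrogen on an aromatic carbon, a change that gave a 1.7-fold higher number from compound 1 to compound 3 (0.23 log units; within the scatter), so compound 3 holds the highest of the three numbers, with compound 1 within the scatter of it and compound 2 beyond it.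

Compound 4 `COc1cc(/C=C2\CN(C)C/C(=C\c3cccc([N+](=O)[O-])c3)C2=O)cc(OC)c1OC` has not yet been measured. It differs from compound 3 by 3-nitrophenyl in place of 3,4-dichlorophenyl on a double-bonded chain carbon bound to a double-bonded ring carbon, the same change that was made from compound 1 to compound 2, the place being described in identical words in both cases. Among the compounds shown this change occurs twice. For compound 4 a step of a 2.1-fold lower number from compound 3 to compound 4 (0.32 log units; beyond the scatter) in this assay is expected, close to the earlier one, because a 2.1-fold lower number from compound 1 to compound 2 (0.33 log units; beyond the scatter) is the only measured instance of this change and nothing shown suggests the core difference alters it. Compound 4 is therefore estimated at 7700 nM, most likely between 3500 nM and 16000 nM.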

Compound 4, half-maximal inhibitory concentration: 4200 nM
Beside the measured number, compound 4's estimate is 1.8-fold (0.26 log units) above it; the measured number falls inside the stated range.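

In this assay, 3-nitrophenyl in place of 3,4-dichlorophenyl again gave a lower number on the methoxy-bearing core, a 3.9-fold lower number from compound 3 to compound 4 (0.59 log units; beyond the scatter), and the size of the step on the two cores cannot be told apart: the same change on two cores in this assay, a 2.1-fold lower number (0.33 log units; beyond the scatter) from compound 1 to compound 2 and a 3.9-fold lower number (0.59 log units; beyond the scatter) from compound 3 to compound 4, 1.8-fold (0.25 log units) apart, within the scatter of two such steps. The added methoxy on an aromatic carbon gave a 1.1-fold lower number from compound 2 to compound 4 (0.02 log units; within the scatter), and on neither core did its step go beyond the scatter: the same change on two cores in this assay, a 1.7-fold higher number (0.23 log units; within the scatter) from compound 1 to compound 3 and a 1.1-fold lower number (0.02 log units; within the scatter) from compound 2 to compound 4, 1.8-fold (0.25 log units) apart, within the scatter of two such steps. Both changes therefore carried across this one pair of cores, but a single pair neither shows that they would carry to other cores nor rules out a real difference between the steps smaller than the scatter.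

The compounds shown leave open whether a nitrile, a trifluoromethyl or an amine in place of the nitro group would give a step of the same kind. They also leave open whether a phenyl bearing a single chlorine would behave as 3,4-dichlorophenyl does.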